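The source may hold more compounds than are shown below. What is called first, only, known or untested is meant among the compounds shown, and "the series" means these compounds.

Of the compounds shown here, three have been measured in an assay on cells for inhibition of cytochrome P450 11B2, mitochondrial (Homo sapiens), read by HPLC, with a stated time of 90 min; on this read-out lower numbers stand for stronger inhibition and higher numbers for weaker inhibition. Compound 1 `Fc1ccc2nc(-c3cnccn3)n(C3CC3)c2c1` gives 541 nM, and compound 2 `Fc1ccc2nc(-c3cccnn3)n(C3CC3)c2c1` gives 412 nM; the step of a 1.3-fold lower number from compound 1 to compound 2 (0.12 log units; within the scatter) exchanges one ring for another on the shared core. Compound 3 `CCc1ncncc1-c1nc2cc(F)c(F)cc2n1C1CC1`, which carries an ethyl on a six-membered aromatic ring with two nitrogens and a second fluorine on the core, gives 8 nM. Its number is the lowest of the three, and the gap to compound 2 and to compound 1 is, in both cases, beyond the scatter, so compound 3 stands clearly apart from the other two.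

Compound 4 `Fc1cc2nc(-c3cncnc3C(F)F)n(C3CC3)c2cc1F` differs from compound 3 in one place: difluoromethyl in place of ethyl on an aromatic carbon. Among the measured compounds shown here, none of the measured steps bears on this change; the only step available, from compound 1 to compound 2, concerns a different ring and lies within the scatter, so it offers no guide to an exchange of ethyl for difluoromethyl. For the measured compounds named here, with no precedent, the expected step from compound 3 to compound 4 in this assay is estimated as a 1.9-fold higher number from compound 3 to compound 4 (0.27 log units; within the scatter), with a wide range in either direction. For compound 4 the estimate in this assay is 15 nM, within a range from 4 nM to 60 nM.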

Compound 4, half-maximal inhibitory concentration: 18 nM
Beside the measured number, compound 4's estimate is 1.2-fold (0.08 log units) below it, within the range that was stated.
By their numbers in this assay, from the lowest: compound 3; then compound 4; then compounds 2 and 1 (each within the scatter of the next).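

In this assay, the exchange of ethyl for difluoromethyl on this aromatic carbon, next to the ring nitrogen and ortho to a large group, gives a 2.3-fold higher number from compound 3 to compound 4 (0.35 log units; beyond the scatter) and is the first step shown at this position. Unlike the earlier ring exchange, which stayed within the scatter, this change lies beyond it, so the read-out does respond to the group at this carbon, although the step is only modest and compound 4 keeps a low number at 18 nM in this assay on this carbon with fluorine present in the group. Nothing available explains why the number rises with this exchange.

Whether methyl, trifluoromethyl or methoxy at the same carbon would hold the number as low, or move it further, stays open among the compounds shown. Also open, going by these compounds, is how much the second fluorine on the core contributes, since compound 3 differs from compounds 1 and 2 in more than one place, and the effect of the ethyl to difluoromethyl exchange on a core with a single fluorine remains unknown.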